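Swapping the sulfonyl aryl group: from dichlorohydroxyphenyl to methoxyphenyl

A few compounds are considered here, and "the series" means these few. Any claim that something is new, unique, unknown or untested is made for them only; others in the source may bear on it.

Of the compounds shown here, three sharing one core have been tested in a functional assay on SUP-B15 cells (Homo sapiens) for antiproliferative activity, with a stated time of 72 h; on this read-out higher numbers stand for an effect only at larger amounts of compound and lower numbers for an effect already at smaller amounts. Compound 1 `COc1ccc(-c2cc(=O)c3c(OC)cc(OC)cc3n2S(=O)(=O)c2ccc(C)c([N+](=O)[O-])c2)cc1` reaches only the limit of the assay, > 51700 nM, so no number is known for it. Compound 2 `COc1ccc(-c2cc(=O)c3c(OC)cc(OC)cc3n2S(=O)(=O)c2ccc(C#N)cc2)cc1` gives 7900 nM in this assay. Compound 3 `COc1ccc(-c2cc(=O)c3c(OC)cc(OC)cc3n2S(=O)(=O)c2cc(Cl)cc(Cl)c2O)cc1` likewise sits at a limit, > 37900 nM, and so stands among the weakest values shown. The step from compound 1 to compound 2 was an at least 6.5-fold lower number from compound 1 to compound 2 (0.81 log units; beyond the scatter), and the step from compound 2 to compound 3 was an at least 4.7-fold higher number from compound 2 to compound 3 (0.68 log units; beyond the scatter); the step from compound 1 to compound 3 is a step that the two limits leave unreadable from compound 1 to compound 3.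

Compound 4 `COc1ccc(-c2cc(=O)c3c(OC)cc(OC)cc3n2S(=O)(=O)c2ccc(OC)cc2)cc1` differs from compound 3 by 4-methoxyphenyl in place of 3,5-dichloro-2-hydroxyphenyl on a sulfonyl sulfur. This change brings the sulfonyl aryl group back to a single small substituent on the ring, as in compound 2. Since the step from compound 2 to compound 3 was an at least 4.7-fold higher number from compound 2 to compound 3 (0.68 log units; beyond the scatter), the reverse direction, a lower number, is expected here, with an expected step of an at least 3.1-fold lower number from compound 3 to compound 4 (0.49 log units; beyond the scatter). Compound 4 is therefore estimated to give about 12000 nM in this assay, within a range of 4000 nM to 40000 nM.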

Compound 4, half-maximal effective concentration: > 82700 nM
Compound 4: no number, only a limit; the forecaster's own chance of this, stated with the estimate: 30%; middle value at least 6.8-fold (0.83 log units) away from the limit.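

Compound 4 gives no number in this assay, only a limit: the limit of > 82700 nM in this assay, at which 1 of the 4 values shown sits.

Its one-place comparison with compound 2 is the informative one: methoxy in place of cyano on an aromatic carbon gives an at least 10-fold higher number from compound 2 to compound 4 (1.01 log units; beyond the scatter). This shows that having a single small substituent on the sulfonyl aryl ring is not enough for a measurable effect in this set, since 4-cyanophenyl gives a number while 4-methoxyphenyl does not. The steps linking compound 4 to compound 1 and compound 3 cannot be read, as all three compounds stand at limits, so these three cannot be put in any order.

From the compounds shown here alone, with compound 2 as the only one of the four to give a number, a single result carries the whole picture, and it remains open whether the nitrile is special or whether other groups on that aromatic carbon would also give a measurable effect, such as an amine, a carboxylic acid or a plain chlorine. Going by these compounds, it also remains open whether the large gap between 4-cyanophenyl and 4-methoxyphenyl would hold on a different core or in other cells.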